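Cytotoxicity notes: chloro in place of fluoro

The compounds below may be only part of what the source reports. "The series", "measured", "known", "first", "only" and "open" are said of these compounds alone.

compound 1 `CONC(=S)N/N=C1\C(=O)N(CN2CCN(c3ccc(Cl)cc3)CC2)c2ccc(Cl)cc21`: 229000 nM
compound 2 `CONC(=S)N/N=C1\C(=O)N(CN2CCN(c3ccc(Cl)cc3)CC2)c2ccc(F)cc21`: 347000 nM
compound 3 `CONC(=S)N/N=C1\C(=O)N(CN2CCN(c3ccc(OC)cc3)CC2)c2ccc(F)cc21`: 276000 nM

All three values come from an ADME assay on MT4 cells (Homo sapiens) for cytotoxicity, read by spectrophotometry, with a stated time of 5 days; a lower number here means that less compound is tolerated, a higher number that more compound is tolerated. Compound 3, at 276000 nM, lies within the scatter of both other compounds, so the three values give no firm order.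

Compound 4 `CONC(=S)N/N=C1\C(=O)N(CN2CCN(c3ccc(OC)cc3)CC2)c2ccc(Cl)cc21` differs from compound 3 in one place: chloro in place of fluoro on an aromatic carbon. The closest evidence is the same exchange in the opposite direction, a 1.5-fold higher number from compound 1 to compound 2 (0.18 log units; within the scatter). The other measured step, a 1.3-fold lower number from compound 2 to compound 3 (0.10 log units; within the scatter), is methoxy in place of chloro at a different place and says little about this exchange. Reversing the first step points to a slightly lower number in this assay, but that step lies within the scatter, so nothing beyond the scatter is expected. The expected step is a 1.3-fold lower number from compound 3 to compound 4 (0.11 log units; within the scatter). For compound 4 the estimated value is 215000 nM, with an expected range of 130000 nM to 340000 nM.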

Compound 4, half-maximal cytotoxic concentration: 221000 nM
The estimate for compound 4 lay 1.0-fold (0.01 log units) below the measured number; measured number inside the range.
By their numbers in this assay, from the lowest: compounds 4, 1, 3 and 2 (each within the scatter of the next).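

In this assay, the exchange at this aromatic carbon of the fused system now has a second reading, a 1.2-fold lower number from compound 3 to compound 4 (0.10 log units; within the scatter), taken with methoxy in place of chloro elsewhere in the molecule. The earlier fluoro and chloro pair therefore no longer stands alone, and the two readings agree within the scatter: the same change on two cores in this assay, a 1.5-fold higher number (0.18 log units; within the scatter) from compound 1 to compound 2 and a 1.2-fold higher number (0.10 log units; within the scatter) from compound 4 to compound 3, 1.2-fold (0.08 log units) apart, within the scatter of two such steps. The methoxy and chloro exchange also gains a second reading, a 1.0-fold lower number from compound 1 to compound 4 (0.02 log units; within the scatter), this time with chloro rather than fluoro at the position on the fused system, and again the two readings agree: the same change on two cores in this assay, a 1.3-fold lower number (0.10 log units; within the scatter) from compound 2 to compound 3 and a 1.0-fold lower number (0.02 log units; within the scatter) from compound 1 to compound 4, 1.2-fold (0.08 log units) apart, within the scatter of two such steps.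

Only fluoro and chloro have been compared at this aromatic carbon, and neither exchange moves the number beyond the scatter. From the compounds shown here alone, whether a nitrile, a carboxylic acid or an amine at this carbon would do so remains open.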